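This account rests on a few compounds, and the source may have more. Where it says the series, first, only, none or still open, it means among the compounds named here.

Compound 1 `NS(=O)(=O)Oc1ccc2c(c1)CN(C(=O)c1cccc(N3CCC(Cc4ccccc4)CC3)c1)CC2`: 1.4%
Compound 2 `NS(=O)(=O)Oc1ccc2c(c1)CN(C(=O)c1ccc(N3CCCCC3)cc1)CC2`: 11.5%
Compound 3 `CC(C)CCN(CCC(C)C)c1ccc(C(=O)N2CCc3ccc(OS(N)(=O)=O)cc3C2)cc1`: 47%

In an assay on HEK293 cells for inhibition of Steryl-sulfatase (Homo sapiens), tested at 0.1 uM (on this read-out higher numbers stand for a stronger effect at the one concentration tested and lower numbers for a weaker effect), compound 1 gives 1.4%, the lowest of the three numbers; compound 2 stands nearest above it and compound 3 furthest, both beyond the scatter. Compound 4 `NS(=O)(=O)Oc1ccc2c(c1)CN(C(=O)c1cccc(N3CCC(N4CCCCC4)CC3)c1)CC2` differs from compound 1 in one place: piperidin-1-yl in place of benzyl on a saturated ring carbon. Among the compounds with values here, the only measured step, a number 35.5 percentage points higher from compound 2 to compound 3 (beyond the scatter), concerns a different group at a different place on the shared core, so it does not bear directly on this change. Within the data shown here, no measured pair shows what exchanging benzyl for piperidin-1-yl on the saturated ring carbon does. The step of a number 4.6 percentage points higher from compound 1 to compound 4 (within the scatter) is therefore expected to be small, without a clear direction beyond the scatter. For compound 4 the estimate is 6%, between 0% and 20%.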

Compound 4, a percentage reported as inhibition, at one concentration (the size of the read-out at that concentration, not a potency): 0%
The estimate for compound 4 lay 6 percentage points above the measured number; measured number inside the range.
By their numbers in this assay, from the lowest: compounds 4 and 1 (each within the scatter of the next); then compound 2; then compound 3.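

Exchanging benzyl for piperidin-1-yl on the saturated ring carbon, in this assay, gives a small step (a number 1.4 percentage points lower from compound 1 to compound 4 (within the scatter)). Within the data shown here, on this position, then, a six-membered non-aromatic ring with one nitrogen and a six-membered aromatic ring of carbon only give numbers that cannot be told apart, which the earlier compounds could not show. Nothing measured here offers an explanation for this result. The compounds shown leave open what a hydroxyl group, a dimethylamino group or a carboxylic acid on this carbon would give.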